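Swapping a Benzyl for an Ester on a Weak Core

This account rests on a few compounds, and the source may have more. Where it says the series, first, only, none or still open, it means among the compounds named here.

compound 1, `N[C@H]1CC[C@H](Nc2c(C(=O)NCc3ccc(F)cc3)nc(N3CCCCC3)c3cccnc23)CC1`: 8000 nM
compound 2, `O=C(NCc1ccc(F)cc1)c1nc(Br)c2cccnc2c1NCc1ccccc1`: > 20000 nM
compound 3, `N[C@H]1CC[C@H](NC(=O)c2nc(Br)c3cccnc3c2NCc2ccc(F)cc2)CC1`: 6400 nM

The three measured compounds share one core and were tested in a functional assay on HCT-116 cells (Homo sapiens) for cytotoxicity, read by MTT assay, with a stated time of 72 h; on this read-out higher numbers stand for weaker inhibition and lower numbers for stronger inhibition. Compound 1 gives 8000 nM and compound 3 gives 6400 nM; these two values lie within the usual scatter of each other. For compound 2 the result is only a limit, > 20000 nM, and not a number. Compound 2 thus stands at the limit of > 20000 nM in this assay, at which 1 of the 3 values shown sits, which is the weakest position the numbers shown can express.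

Compound 4, `COC(=O)CNc1c(C(=O)NCc2ccc(F)cc2)nc(Br)c2cccnc12`, has not been measured. It differs from compound 2 in one place: methoxycarbonyl in place of phenyl on a saturated chain carbon bound to a nitrogen on an aromatic ring. Within the data shown here, no measured pair of compounds shows this same change, so there is no step to lean on. The step of a number no higher from compound 2 to compound 4 (the limit leaves the size open) is expected to be small, with neither direction favoured, and not beyond the scatter in this assay. Compound 4 is therefore estimated at 20000 nM, in a range from 7000 nM to 60000 nM, and a limit rather than a number is the likelier outcome.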

Compound 4, half-maximal inhibitory concentration: > 10000 nM
Compound 4 ended at the assay's limit; the forecaster's own chance of this, stated with the estimate: 60%; the middle value is on the limit's open side.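

Among these compounds, compound 2 and compound 4 both ended at limits of the assay rather than at numbers, so no step between them can be read. As far as these compounds go, whether methoxycarbonyl in place of phenyl changes the result in this assay, and in which direction, stays open.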